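Notes on the step from compound 3 to compound 4

The compounds below may be only part of what the source reports. "The series", "measured", "known", "first", "only" and "open" are said of these compounds alone.

In a physicochemical assay for solubility, using the shake flask method, in phosphate buffer, measured as kinetic solubility, with a stated time of 20 h, at pH 6.5 (a higher number here means a more soluble compound, a lower number a less soluble compound), compound 1 `FC(F)(F)c1cccc(-c2nc3cnc(Nc4ccccn4)cc3[nH]2)c1` gives < 5000 nM, a limit and not a number. Compound 2 `FC(F)(F)c1cccc(-c2nc3cnc(Nc4ccncn4)cc3[nH]2)c1` gives < 5000 nM, also a limit. Compound 3 `FC(F)(F)c1cccc(-c2nc3cnc(Nc4cnccn4)cc3[nH]2)c1` gives < 5000 nM, again a limit. Among the measured compounds shown here, the whole series so far stands at one place: the limit of < 5000 nM in this assay, at which 3 of the 3 values shown sit.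

Compound 4 `Fc1cnc(Nc2cc3[nH]c(-c4cccc(C(F)(F)F)c4)nc3cn2)c(F)c1` differs by 3,5-difluoropyridin-2-yl in place of pyrazin-2-yl on a nitrogen on an aromatic ring, with 3,5-difluoropyridin-2-yl in place of pyrazin-2-yl on a nitrogen on an aromatic ring. The nearest steps, a step that the two limits leave unreadable from compound 1 to compound 2, a step that the two limits leave unreadable from compound 1 to compound 3 and a step that the two limits leave unreadable from compound 2 to compound 3, change the same group, but none has a readable size. No step beyond the scatter is therefore expected, and the estimated step is a step that the limit leaves unreadable from compound 3 to compound 4. For compound 4 the expected value is 2500 nM, with an estimated range from 800 nM to 5000 nM.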

Compound 4, solubility: < 5000 nM
Compound 4: no number, only a limit (the forecaster's own chance of this, stated with the estimate: 80%); the middle value lies beyond the limit too.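

In this assay, among the compounds shown here, compound 4 gives < 5000 nM, a limit and not a number, so no step linking it to compound 1, compound 2 or compound 3 can be read. How these four compounds compare in this assay stays open: the limit of < 5000 nM in this assay, at which 4 of the 4 values shown sit.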